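Regioisomeric methoxyphenoxy group in a bile acid receptor series

The source may report more compounds than this note shows. Statements on the series, on what has been measured and on what is new or still open speak of the compounds shown alone.

Measured compounds:
- compound 1, `Cc1nn(-c2ccccc2Cl)c2c1C(c1ccc(Oc3ccccc3)cc1)SC(C)C(=O)N2`: 2700 nM
- compound 2, `COc1ccc(Oc2ccc([C@H]3S[C@@H](C)C(=O)Nc4c3c(C)nn4-c3ccccc3C)cc2)cc1`: 2200 nM
- compound 3, `CCOc1cccc(-c2ccc([C@H]3S[C@@H](C)C(=O)Nc4c3c(C)nn4-c3ccccc3C)cc2)c1`: 3500 nM

In an assay on isolated protein for agonist activity at Bile acid receptor (Homo sapiens), read by AlphaScreen, with a stated time of 30 min (a higher number here means that more compound is needed for the effect, a lower number that less compound is needed), compound 3 gives 3500 nM. Its distance from compound 1 and from compound 2 is within the scatter, so no ranking among the three measured compounds can be drawn from these numbers. The unmeasured compound 4, `COc1ccccc1Oc1ccc([C@H]2S[C@@H](C)C(=O)Nc3c2c(C)nn3-c2ccccc2C)cc1`, arises from compound 3 by a single change: 2-methoxyphenoxy in place of 3-ethoxyphenyl on an aromatic carbon. Within the data shown here, the only measured step at this position is a 1.6-fold higher number from compound 2 to compound 3 (0.20 log units; within the scatter), which is within the scatter and shows that swapping an ethoxyphenyl for a methoxyphenoxy group at this place did not move the number beyond chance variation. Compound 1, which carries a plain phenoxy group here together with a different substituent elsewhere, lies at a similar number. Since compound 4 returns to a methoxyphenoxy group, now with the methoxy in the 2-position, the expected step is small, a 1.4-fold lower number from compound 3 to compound 4 (0.15 log units; within the scatter), pointing toward compound 2's value. Compound 4 is therefore estimated at 2500 nM in this assay, with a range from 1200 nM to 5500 nM.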

Compound 4, half-maximal effective concentration: 1700 nM
Beside the measured number, compound 4's estimate is 1.5-fold (0.17 log units) above it, within the range that was stated.
By their numbers in this assay, from the lowest: compounds 4, 2, 1 and 3 (each within the scatter of the next, the first and the last beyond it).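

In this assay, among these compounds, the change from 3-ethoxyphenyl to 2-methoxyphenoxy gives a 2.1-fold lower number from compound 3 to compound 4 (0.31 log units; beyond the scatter), the first step at this position to pass beyond the scatter, although only modestly; the earlier swap to a 4-methoxyphenoxy group, a 1.6-fold higher number from compound 2 to compound 3 (0.20 log units; within the scatter), did not. Moving the methoxy group around the outer ring, from 4-methoxyphenyl to 2-methoxyphenyl on the oxygen, gives a 1.3-fold lower number from compound 2 to compound 4 (0.11 log units; within the scatter), so these two compounds cannot be told apart, and the place of the methoxy group has no readable effect here. Nothing shown gives a reason for either step.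

On these data alone, the 3-methoxyphenoxy isomer remains open, so the methoxy series is incomplete. It is also unknown how an amine or a carboxylic acid in place of the methoxy group would read in this assay.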